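This account rests on a few compounds, and the source may have more. Where it says the series, first, only, none or still open, it means among the compounds named here.

In a functional assay on NCI-H1975 cells (Homo sapiens) for inhibition, read by sulforhodamine B assay, tested at 10 uM (a higher number here means more inhibition at the concentration tested (going by the name of the read-out), a lower number less inhibition), compound 1 `CC(=O)N1N=C(c2ccc(-n3cncn3)cc2)CC1c1ccc(N(C)C)cc1` gives -0.3%. Compound 2 `CN(C)c1ccc(C2CC(c3ccc(-n4cncn4)cc3)=NN2S(=O)(=O)c2ccc(C(F)(F)F)cc2)cc1` gives 5.5%, the larger of the two numbers on record, though its gap to compound 1 lies within the scatter, and neither compound shows appreciable inhibition at the tested concentration. Compound 3 `CN(C)c1ccc(C2CC(c3ccc(-n4cncn4)cc3)=NN2S(=O)(=O)c2ccc(C#N)cc2)cc1` differs from compound 2 by cyano in place of trifluoromethyl on an aromatic carbon. With both measured compounds sitting near zero in this assay, the change is expected to bring no step beyond the scatter, an expected shift of a number 1.5 percentage points lower from compound 2 to compound 3 (within the scatter). Compound 3 is accordingly estimated at 4%, within a range from -8% to 16%.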

Compound 3, a percentage reported as inhibition, at one concentration (the size of the read-out at that concentration, not a potency): 22.6%
Estimate against measurement, compound 3: 18.6 percentage points below; the measured number lies above the stated range.
By their numbers in this assay, from the lowest: compounds 1 and 2 (each within the scatter of the next); then compound 3.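

In this assay the group on this aromatic carbon, para to a large group, does register: cyano in place of trifluoromethyl brings a number 17.1 percentage points higher from compound 2 to compound 3 (beyond the scatter) and gives the first separation in the series. (4-cyanophenyl)sulfonyl in place of acetyl on the ring amine nitrogen brings a number 22.9 percentage points higher from compound 1 to compound 3 (beyond the scatter), while compound 2, which also has an arylsulfonyl group, stays within the scatter of compound 1. So the sulfonyl group alone does not account for the rise in these compounds.

No measurement shown gives a reason for the gain. On these data alone, whether an amine, a carboxylic acid or a methoxy group on this carbon would hold or extend it remains open.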